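Dropping a Trifluoromethyl Group: What to Expect Next

This account rests on a few compounds, and the source may have more. Where it says the series, first, only, none or still open, it means among the compounds named here.

Of the compounds shown here, two have been measured so far. Compound 1 `COc1cc(/C=N/Nc2nc(-c3ccccc3)cs2)c(Br)c(Br)c1OC` and compound 2 `COc1cc(/C=N/Nc2nc(-c3ccc(C(F)(F)F)cc3)cs2)cc(Br)c1OC` share a core and differ in more than one place. In a functional assay on A549 cells (Homo sapiens) for inhibition, read by MTT assay, with a stated time of 48 h (on this read-out lower numbers stand for stronger inhibition and higher numbers for weaker inhibition), compound 1 gives 15300 nM, and in this assay compound 2 gives 18300 nM. Compound 2 stands at the top of the two numbers, yet compound 1 sits within the scatter of it, so the two cannot be told apart. Compound 3 `COc1cc(/C=N/Nc2nc(-c3ccccc3)cs2)cc(Br)c1OC` is not yet measured and differs from compound 2 in one place: hydrogen in place of trifluoromethyl on an aromatic carbon. Among the measured compounds shown here, no such step exists between measured compounds, so the expected step of a 1.1-fold lower number from compound 2 to compound 3 (0.06 log units; within the scatter) stays within the scatter. Compound 3 is estimated at 16000 nM, between 6000 nM and 45000 nM.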

Compound 3, half-maximal inhibitory concentration: 40000 nM
The estimate for compound 3 lay 2.5-fold (0.40 log units) below the measured number; measured number inside the range.
By their numbers in this assay, from the lowest: compounds 1 and 2 (each within the scatter of the next); then compound 3.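

In this assay, hydrogen in place of trifluoromethyl gives a 2.2-fold higher number from compound 2 to compound 3 (0.34 log units; beyond the scatter) and so weakens inhibition, a single-place effect that compound 1 and compound 2, which differ in more than one place, could not reveal. Hydrogen in place of bromo gives a 2.6-fold higher number from compound 1 to compound 3 (0.42 log units; beyond the scatter) in the same direction, so each group is better than hydrogen at its own position. Nothing available explains why either group helps. Going by these compounds, whether an amine or a carboxylic acid on that aromatic carbon would match trifluoromethyl stays open.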